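Propargylamine truncation on the indole series: compound 2 to 4

The source may report more compounds than this note shows. Statements on the series, on what has been measured and on what is new or still open speak of the compounds shown alone.

Compound 2 `CC#CCN(C)Cc1cc2cc(O)ccc2n1C` holds the lowest number of the three measured in an assay on isolated protein for inhibition of Amine oxidase [flavin-containing] A (Rattus norvegicus) (a lower number here means a stronger inhibitor, a higher number a weaker inhibitor), giving 5.7 nM. Within the data shown here, compound 1 `c1ccc(CNCc2cn(Cc3ccccc3)c3ccccc23)cc1` gives 244000 nM in this assay, and compound 3 `CCNCc1cn(Cc2ccccc2)c2ccccc12` gives 262000 nM; the one measured step, a 1.1-fold higher number from compound 1 to compound 3 (0.03 log units; within the scatter), sits at the weak end of the series and changes nothing beyond the scatter. Compound 4 `C#CCNCc1cc2cc(O)ccc2n1C` is the next member. The change from compound 2 is propargylamino in place of (but-2-yn-1-yl)(methyl)amino on a saturated chain carbon bound to an aromatic carbon: the methyl on the amine nitrogen is lost and the but-2-yn-1-yl is shortened to propargyl, with one hydrogen-bond donor entering. Among the measured compounds shown here, no measured step touches the amine substituents of compound 2, so the step from compound 1 to compound 3 does not bear on it and the size of the move in this assay cannot be read from the series. The loss of two carbons from the amine side is expected to cost potency, and a weakening step of an 18-fold higher number from compound 2 to compound 4 (1.24 log units; beyond the scatter) is estimated. Compound 4 is therefore expected to give 100 nM, within 20 nM to 800 nM.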

Compound 4, inhibition constant: 4000 nM
Compound 4: the middle estimate sits 40-fold (1.60 log units) below what was measured; the measured number lies above the stated range.
By their numbers in this assay, from the lowest: compound 2; then compound 4; then compounds 1 and 3 (each within the scatter of the next).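

In this assay, the amine substituents on the saturated chain carbon bound to an aromatic carbon prove to be a steep point in the series, with a 700-fold higher number from compound 2 to compound 4 (2.85 log units; beyond the scatter) as a large weakening. The earlier step, a 1.1-fold higher number from compound 1 to compound 3 (0.03 log units; within the scatter), lies within the scatter at the weak end and gave no sign of such sensitivity to an amine substituent. No measurement shown gives a reason for the size of this step.

Going by these compounds, the step combines loss of the methyl on the amine nitrogen with shortening of but-2-yn-1-yl to propargyl, so the share of each remains open. A (methyl)(propargyl)amino group or a but-2-yn-1-ylamino group on the same carbon would separate the two changes.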